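The source may report more compounds than this note shows. Statements on the series, on what has been measured and on what is new or still open speak of the compounds shown alone.

- compound 1 `CCCCCC=C(c1cc(Cl)c(OC)c(C(=O)OC)c1)c1cc(Cl)c(OC)c(C(=O)OC)c1`: > 29000 nM
- compound 2 `COC(=O)CCCC=C(c1cc(Br)c(OC)c(C(=O)OC)c1)c1cc(Br)c(OC)c(C(=O)OC)c1`: 13000 nM

These two values come from an ADME assay on CEM-SS cells (Homo sapiens) for cytotoxicity; on this read-out lower numbers stand for higher toxicity in this test and higher numbers for lower toxicity in this test. Compound 1 reads > 29000 nM, which is a limit of the assay and not an exact number. Within the data shown here, compound 2 gives 13000 nM, the only exact number so far, so it serves as the reference point here.

Compound 3 `COC(=O)c1cc(C(=CCCCc2ccccc2)c2cc(Br)c(OC)c(C(=O)OC)c2)cc(Br)c1OC` has not yet been measured. It keeps the shared core of compound 2 and changes the chain (phenyl in place of methoxycarbonyl on a saturated chain carbon, three bonds along the chain from a double-bonded chain carbon). Among the measured compounds shown here, no measured pair shows this swap, so only a small change of uncertain direction is expected, and a 1.2-fold higher number from compound 2 to compound 3 (0.06 log units; within the scatter) is estimated to stay within the usual scatter. The estimate for compound 3 is 15000 nM, with an expected range of 5000 nM to 40000 nM.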

Compound 3, half-maximal cytotoxic concentration: > 200000 nM
Compound 3: only a limit was reported (the forecaster's own chance of this, stated with the estimate: 30%); middle value at least 13-fold (1.12 log units) from the limit.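

In this assay, putting phenyl in place of methoxycarbonyl on a saturated chain carbon, three bonds along the chain from a double-bonded chain carbon, gives an at least 15-fold higher number from compound 2 to compound 3 (1.18 log units; beyond the scatter), which means lower toxicity in this test. Among these compounds, this is the first sign that the group at this position of the chain can shift the read-out strongly while the shared core stays the same. The true size of the step is not known, since compound 3 gives only a limit of the assay and not an exact number: the limit of > 200000 nM in this assay, at which 1 of the 3 values shown sits.

Going by these compounds, whether another group in this place, such as a carboxylic acid or an amine, would read closer to compound 2 or to compound 3 remains open. Compound 1 differs from compound 2 in more than one place, so it cannot show what the chain alone does.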